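Working notes: 3,5-dimethylphenyl for 2-bromophenyl, cytotoxicity

This account rests on a few compounds, and the source may have more. Where it says the series, first, only, none or still open, it means among the compounds named here.

Measured so far:
compound 1 `COc1ccc(CSc2nc(Cc3ccccc3Br)c(C)c(=O)[nH]2)cc1`: 179000 nM
compound 2 `Cc1c(Cc2ccccc2Br)nc(SCc2ccc([N+](=O)[O-])cc2)[nH]c1=O`: >= 246000 nM (a limit of the assay, not a number)

In an ADME assay on MT4 cells (Homo sapiens) for cytotoxicity, read by MTT assay (a higher number here means that more compound is tolerated, a lower number that less compound is tolerated), compound 1 gives 179000 nM. Going by the values given here, this is the only plain number among the two values shown; the other value is the limit of >= 246000 nM in this assay, at which 1 of the 2 values shown sits, and belongs to compound 2. Among the compounds with values here, the one measured step, nitro in place of methoxy on an aromatic carbon, reads an at least 1.3-fold higher number from compound 1 to compound 2 (0.13 log units; that floor lies within the scatter). That change sits on a part of the molecule that compound 3 keeps unchanged, so it says nothing direct about the step considered here.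

Compound 3 is `COc1ccc(CSc2nc(Cc3cc(C)cc(C)c3)c(C)c(=O)[nH]2)cc1`. Its difference from compound 1 is 3,5-dimethylphenyl in place of 2-bromophenyl on a saturated chain carbon bound to an aromatic carbon. Within the data shown here, no measured step in this assay touches the group on the saturated chain carbon bound to an aromatic carbon, so there is no basis for expecting a shift in either direction beyond the scatter. The estimate for compound 3 therefore stays at the level of compound 1: an expected step of a 1.0-fold higher number from compound 1 to compound 3 (0.00 log units; within the scatter). Compound 3 is expected to give 180000 nM in this assay, with a range from 80000 nM to 360000 nM.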

Compound 3, half-maximal cytotoxic concentration: > 329000 nM
Compound 3: only a limit was reported; the forecaster's own chance of this, stated with the estimate: 30%; at least 1.8-fold (0.26 log units) between middle value and limit.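

Going by these compounds alone, replacing 2-bromophenyl with 3,5-dimethylphenyl on a saturated chain carbon bound to an aromatic carbon gives the first reading for this position in this assay: an at least 1.8-fold higher number from compound 1 to compound 3 (0.26 log units; that floor lies within the scatter). The reading for compound 3 is a limit of the assay, > 329000 nM, and not a number. The position therefore accepts the loss of the bromine and the gain of two methyl groups with no drop in the tolerated concentration relative to compound 1, while the floor of the step does not establish a real rise and the true size of the step cannot be read.

The compounds shown do not separate the effect of removing the bromine from that of adding the two methyl groups, and a plain phenyl group at this place would be needed to tell the two apart. Also open, going by these compounds, is whether this position stays as tolerant with a group of another kind, such as an amine or a carboxylic acid on the ring, or with a longer chain leading to it.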